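A few compounds are considered here, and "the series" means these few. Any claim that something is new, unique, unknown or untested is made for them only; others in the source may bear on it.

The three measured compounds share the core of compound 1 `NC(=O)c1ccc(C#Cc2ccccc2)nc1`, which in a functional assay on BHK cells for positive allosteric modulation of metabotropic glutamate receptor 5 (Homo sapiens), read by FLIPR and calcium flux (a lower number here means that less compound is needed, a higher number that more compound is needed for the effect), gives 6600 nM. Compound 2 `O=C(NC1CCCCC1)c1ccc(C#Cc2ccccc2)nc1` carries a cyclohexyl group on the amide nitrogen and in this assay gives 240 nM. Compound 3 `CC1CCC(NC(=O)c2ccc(C#Cc3ccccc3)nc2)CC1` carries a 4-methylcyclohexyl group there and in this assay gives 1200 nM. Among the three numbers compound 3 stands second: the step of a 5.0-fold higher number from compound 2 to compound 3 (0.70 log units; beyond the scatter) sets it apart from compound 2, and the step of a 5.5-fold lower number from compound 1 to compound 3 (0.74 log units; beyond the scatter) sets it apart from compound 1, each beyond the scatter.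

Compound 4 `CC1CCN(C(=O)c2ccc(C#Cc3ccccc3)nc2)CC1` is the next step, and the change is 4-methylpiperidin-1-yl in place of (4-methylcyclohexyl)amino on a carbonyl carbon. The saturated six-membered ring and its methyl stay, but the ring now holds the nitrogen itself, and the hydrogen on the amide nitrogen is gone. Among the compounds with values here, two measured steps touch this spot, a 28-fold lower number from compound 1 to compound 2 (1.44 log units; beyond the scatter) and a 5.5-fold lower number from compound 1 to compound 3 (0.74 log units; beyond the scatter), and both show that a saturated ring on that nitrogen lowers the number; the step of a 5.0-fold higher number from compound 2 to compound 3 (0.70 log units; beyond the scatter) shows that the methyl raises it. Within the data shown here, none of these steps removes the amide hydrogen, so no measured step matches the present change in kind. The step from compound 3 to compound 4 is expected to be a 2.5-fold higher number from compound 3 to compound 4 (0.40 log units; beyond the scatter), with wide uncertainty. Compound 4 is therefore estimated at 3000 nM, within a range from 500 nM to 20000 nM.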

Compound 4, half-maximal effective concentration: 130 nM
For compound 4 the middle estimate is 23-fold (1.36 log units) above the measured one, and the stated range ends above it.
By their numbers in this assay, from the lowest: compounds 4 and 2 (each within the scatter of the next); then compound 3; then compound 1.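

In this assay, within the data shown here, the change to 4-methylpiperidin-1-yl gives a 9.2-fold lower number from compound 3 to compound 4 (0.97 log units; beyond the scatter) and is the first change in this set that takes away the amide hydrogen, so a low number at this position does not depend on that hydrogen being present. The ring can also hold the amide nitrogen itself and still lower the number: the unsubstituted amide goes to this group with a 51-fold lower number from compound 1 to compound 4 (1.71 log units; beyond the scatter) in the same direction as the earlier rings placed on that nitrogen. With a 1.8-fold lower number from compound 2 to compound 4 (0.27 log units; within the scatter) the two compounds lie within the scatter of each other, so the methyl-bearing ring built around the nitrogen and the plain cyclohexyl on it cannot be told apart in this assay here.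

A plain piperidin-1-yl without the methyl would show whether the methyl raises the number on this ring as it did on the cyclohexyl, and a methyl on the amide nitrogen of compound 2 would separate the loss of the amide hydrogen from the change of ring. No other measurement is at hand that would explain the size of these steps.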